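The source may hold more compounds than are shown below. What is called first, only, known or untested is meant among the compounds shown, and "the series" means these compounds.

In a functional assay on K562 cells (Homo sapiens) for cytotoxicity, read by fluorescence, with a stated time of 72 h (a lower number here means a stronger inhibitor, a higher number a weaker inhibitor), compound 1 (`CSc1nc(NCc2ccc(-c3ccccn3)cc2)c2[nH]nc(C(C)C)c2n1`) gives 778 nM and compound 2 (`CC(C)c1n[nH]c2c(NCc3ccc(-c4ccccn4)cc3)nc(NCC(C)(C)O)nc12`) gives 29 nM on the same core, while compound 3 (`CC(C)c1n[nH]c2c(NCc3ccc(-c4ccccn4)cc3)nc(NCC(N)CO)nc12`) gives 700 nM at the upper end of these numbers, level with compound 1. The steps that place it there are a 1.1-fold lower number from compound 1 to compound 3 (0.05 log units; within the scatter) and a 24-fold higher number from compound 2 to compound 3 (1.38 log units; beyond the scatter) in all. Compound 4 (`CC(C)c1n[nH]c2c(NCc3ccc(-c4ccccn4)cc3)nc(N3CCNCC3)nc12`) replaces the ringless group of compound 3 with piperazin-1-yl on the same aromatic carbon (a group of 6 heavy atoms (4 carbon, 2 nitrogen; one six-membered non-aromatic ring with 2 hetero atoms) in place of a group of 6 heavy atoms (3 carbon, 2 nitrogen, 1 oxygen; no ring), on an aromatic carbon). Going by the values given here, the step of a 27-fold lower number from compound 1 to compound 2 (1.43 log units; beyond the scatter) shows that a change at this carbon can be large, yet no measured compound carries a ring there. A moderate step to a lower number is therefore expected in this assay (a 3.5-fold lower number from compound 3 to compound 4 (0.54 log units; beyond the scatter)). Compound 4 is estimated at 200 nM (range 50 nM to 800 nM).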

Compound 4, half-maximal inhibitory concentration: 17 nM
Compound 4: middle estimate off by 12-fold (1.07 log units), on the high side; measured number outside the range, below it.
By their numbers in this assay, from the lowest: compounds 4 and 2 (each within the scatter of the next); then compounds 3 and 1 (each within the scatter of the next).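

In this assay, a ring can stand on this aromatic carbon between two ring nitrogen atoms with a large shift to a lower number: a 41-fold lower number from compound 3 to compound 4 (1.61 log units; beyond the scatter) and a 46-fold lower number from compound 1 to compound 4 (1.66 log units; beyond the scatter). Against the ringless (2-hydroxy-2-methylpropyl)amino, piperazin-1-yl brings no difference beyond the scatter, at a 1.7-fold lower number from compound 2 to compound 4 (0.23 log units; within the scatter), so a ring and a chain can both give numbers at this level. Nothing available explains these differences. The compounds shown leave open whether the ring or its second nitrogen matters, which a morpholine or a piperidine on the same carbon would separate.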